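The compounds below may be only part of what the source reports. "The series", "measured", "known", "first", "only" and "open" are said of these compounds alone.

In an ADME assay on MT4 cells (Homo sapiens) for cytotoxicity, read by MTT assay (on this read-out higher numbers stand for lower toxicity in this test and lower numbers for higher toxicity in this test), compound 2 (`O=C(CSc1nncnc1-c1ccccc1Cl)c1ccc(Br)cc1Br`) stands lowest of the two measured compounds at 28000 nM, while compound 1 (`O=C(CSc1nncnc1-c1ccccc1Cl)Nc1ccccc1Br`) gives 73000 nM. Going to compound 3 (`Cc1ccccc1NC(=O)CSc1nncnc1-c1ccccc1Cl`) brings (2-methylphenyl)amino in place of 2,4-dibromophenyl on a carbonyl carbon. Within the data shown here, the one measured step bearing on this is a 2.6-fold lower number from compound 1 to compound 2 (0.42 log units; beyond the scatter), modest but beyond the scatter, and it left (2-bromophenyl)amino where compound 3 again has a phenylamino group. A step of similar size in the reverse direction is therefore expected in this assay, an estimated 2.3-fold higher number from compound 2 to compound 3 (0.37 log units; beyond the scatter). The expected value for compound 3 is 65000 nM, within a range of 28000 nM to 150000 nM.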

Compound 3, half-maximal cytotoxic concentration: 142000 nM
Compound 3: the middle estimate sits 2.2-fold (0.34 log units) below what was measured; the measured number falls inside the stated range.
By their numbers in this assay, from the lowest: compound 2; then compounds 1 and 3 (each within the scatter of the next).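

In this assay, replacing 2,4-dibromophenyl with (2-methylphenyl)amino on the carbonyl carbon gave a 5.1-fold higher number from compound 2 to compound 3 (0.71 log units; beyond the scatter), so this change moves the number as the earlier step did, in the opposite direction. Methyl in place of bromo on an aromatic carbon gave a 1.9-fold higher number from compound 1 to compound 3 (0.29 log units; within the scatter), so the amino-linked ring tolerates either group in this test. No evidence is available on the cause of either step.

Open, going by these compounds, is whether the amide hydrogen or the ring's bromines carry the larger step, since both differ at once. On these data alone, how a methoxy group or a carboxylic acid on that ring would read also remains open.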